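This account rests on a few compounds, and the source may have more. Where it says the series, first, only, none or still open, it means among the compounds named here.

Working notes on the series. The parent is compound 1 `COc1ccc(S(=O)(=O)/C=C/c2ccccn2)cc1`. In an assay on U2OS cells for activation of nuclear factor erythroid 2-related factor 2 (Homo sapiens), read by chemiluminescence, with a stated time of 6 h (on this read-out higher numbers stand for an effect only at larger amounts of compound and lower numbers for an effect already at smaller amounts), compound 1 reaches only the limit of the assay, > 10000 nM, and not a number. Where compound 1 stands is thus known only as a limit: the limit of > 10000 nM in this assay, at which 1 of the 2 values shown sits. Compound 2 `COc1ccc(S(=O)(=O)/C=C/c2cccc(Cl)n2)cc1` carries chloro in place of hydrogen on an aromatic carbon of the shared core, and in this assay compound 2 gives 3270 nM. Among the compounds with values here, the single measured step is an at least 3.0-fold lower number from compound 1 to compound 2 (0.48 log units; beyond the scatter). Compound 3 `COc1ccc(S(=O)(=O)/C=C/c2ccc(Cl)cn2)cc1` is not yet measured; it differs from compound 1 by chloro in place of hydrogen on an aromatic carbon. Within the data shown here, the measured step that bears on it is the one from compound 1 to compound 2, also a chloro for hydrogen on the same ring, though not on the same aromatic carbon. Expectation for this assay: a step from compound 1 to compound 3 in the same direction, toward lower numbers and of at least modest size, with the reservation that a limit rather than a number may again result. The estimate for compound 3 is 5000 nM, with a range from 1500 nM to 20000 nM, corresponding to an expected step of an at least 2.0-fold lower number from compound 1 to compound 3 (0.30 log units; that floor lies within the scatter).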

Compound 3, half-maximal effective concentration: 9360 nM
For compound 3 the middle estimate is 1.9-fold (0.27 log units) below the measured one; measured number inside the range.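

Chloro in place of hydrogen on this aromatic carbon, two atoms from the ring nitrogen and para to a large group, gives in this assay an at least 1.0-fold lower number from compound 1 to compound 3 (0.02 log units; that floor lies within the scatter), against an at least 3.0-fold lower number from compound 1 to compound 2 (0.48 log units; beyond the scatter) for the same exchange on a different carbon of the ring. The step beyond the scatter seen with compound 2 is therefore not reproduced at this position, so the same exchange cannot be treated as equivalent on the two carbons: compound 2 gives 3270 nM and compound 3 gives 9360 nM. Compound 1 is held only at a limit, > 10000 nM, and not at a number, so the true size of its step to compound 3 cannot be read: the limit of > 10000 nM in this assay, at which 1 of the 3 values shown sits.

The compounds shown leave open whether a fluoro, a methyl or an amine on these same two carbons would follow chloro, and with only two placements on the ring no trend across positions can be drawn. Also open, from the compounds shown here alone, is what chloro does on the remaining carbons of this ring, and whether a carboxylic acid or a longer chain would be accepted at either position.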